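The source may hold more compounds than are shown below. What is called first, only, known or untested is meant among the compounds shown, and "the series" means these compounds.

Measured compounds:
- compound 1, `COC(=O)CC1CCN(C[C@H]2CN(c3ccc(-n4cc(-c5ccccn5)cn4)c(F)c3)C(=O)O2)CC1`: 92100 nM
- compound 2, `O=C1CNC(=O)N1C[C@H]1CN(c2ccc(-n3cc(-c4ccccn4)cn3)c(F)c2)C(=O)O1`: 1630000 nM

The assay in question is a physicochemical assay for solubility, read by HPLC, with a stated time of 24 h; a lower number here means a less soluble compound, a higher number a more soluble compound. Among the two numbers available, compound 1 stands lowest, and its nearest neighbour is compound 2, reached by an 18-fold higher number from compound 1 to compound 2 (1.25 log units; beyond the scatter). Going by the values given here, that step exchanges the piperidine-bearing group on the saturated chain carbon for a cyclic imide and is the only measured change that bears on the present question.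

The unmeasured compound is compound 3, `CCNC(=O)NC[C@H]1CN(c2ccc(-n3cc(-c4ccccn4)cn3)c(F)c2)C(=O)O1`. The change from compound 1 is (ethylcarbamoyl)amino in place of 4-((methoxycarbonyl)methyl)piperidin-1-yl on a saturated chain carbon bound to a saturated ring carbon. Like the step to compound 2, it removes the 4-((methoxycarbonyl)methyl)piperidin-1-yl group and puts a small urea-type fragment with hydrogen-bond donors in its place, so the step to compound 2 is the closest guide, though the entering group is a chain rather than a ring and the outcome need not match in size.

Compound 3 is therefore expected to give a higher number than compound 1 in this assay, with an expected step of a 5.4-fold higher number from compound 1 to compound 3 (0.73 log units; beyond the scatter). The estimate for compound 3 is 500000 nM, within a range of 100000 nM to 2000000 nM.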

Compound 3, solubility: 222000 nM
Compound 3: the middle estimate sits 2.3-fold (0.35 log units) above what was measured, within the range that was stated.
By their numbers in this assay, from the lowest: compound 1; then compound 3; then compound 2.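

In this assay, the open-chain (ethylcarbamoyl)amino group, placed on a saturated chain carbon bound to a saturated ring carbon, also gives a higher number than the 4-((methoxycarbonyl)methyl)piperidin-1-yl group (a 2.4-fold higher number from compound 1 to compound 3 (0.38 log units; beyond the scatter)), so the upward step is no longer tied to the 2,5-dioxoimidazolidin-1-yl ring alone and two different entering groups now point the same way. The two entering groups are not interchangeable, however, since the ring-free group falls well short of the ring (a 7.3-fold lower number from compound 2 to compound 3 (0.87 log units; beyond the scatter)), which shows that the number at this position depends on which group enters and not only on which group leaves. Nothing available explains why these groups rank in this order.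

Going by these compounds, it remains open whether a primary amine, an acetamide or a carboxylic acid on the same saturated chain carbon would land nearer compound 3 or compound 2, and whether a longer chain in place of the ethyl of the (ethylcarbamoyl)amino group would shift the number. All three compounds also share one core, so these compounds cannot show whether the same order holds on a different core.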